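This account rests on a few compounds, and the source may have more. Where it says the series, first, only, none or still open, it means among the compounds named here.

In a functional assay on HT-29 cells (Homo sapiens) for inhibition, with a stated time of 72 h (a lower number here means a stronger inhibitor, a higher number a weaker inhibitor), measured so far:
compound 1 `COc1ccc(S(=O)(=O)N2CCc3cccc(-c4ccc(N(C)C)cc4)c32)cc1`: 467 nM
compound 2 `COc1ccc(S(=O)(=O)N2CCc3cccc(-c4cc(OC)c(OC)c(OC)c4)c32)cc1`: 5100 nM
compound 3 `COc1ccc(S(=O)(=O)n2ccc3cccc(-c4ccc(F)cc4)c32)cc1`: 196 nM

Of these three numbers, compound 1 holds the middle place at 467 nM. The nearest number is that of compound 3 at 196 nM, lower by more than the scatter. The furthest is that of compound 2 at 5100 nM, higher by more than the scatter.

Still unmeasured is compound 4 `COc1ccc(S(=O)(=O)N2CCc3cccc(-c4ccc(C#N)cc4)c32)cc1`. It keeps the core of compound 1 and carries cyano in place of dimethylamino on an aromatic carbon, para to a large group: cyano in place of dimethylamino on an aromatic carbon.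

Among the compounds with values here, no two measured compounds differ in one place only, so this change has no direct measured precedent. Within the data shown here, the numbers show only that values on the core of compound 1 can lie far apart, as compound 2 at 5100 nM does. With so little to go on, no shift beyond the scatter is expected in this assay, in either direction. The expected size is a 1.2-fold higher number from compound 1 to compound 4 (0.07 log units; within the scatter), an estimate that stays within the scatter. For compound 4 the estimated value is 550 nM, with an expected range of 180 nM to 1700 nM.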

Compound 4, half-maximal inhibitory concentration: 24.2 nM
Compound 4: middle estimate off by 23-fold (1.36 log units), on the high side; the whole stated range lies above it.
By their numbers in this assay, from the lowest: compound 4; then compound 3; then compound 1; then compound 2.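

In this assay, within the data shown here, cyano in place of dimethylamino on an aromatic carbon, para to a large group, gives a 19-fold lower number from compound 1 to compound 4 (1.29 log units; beyond the scatter), the first one-place comparison and a large one. It shows that on the core of compound 1 this single substituent can carry the number well beyond the scatter, even though the two groups match in the counted hydrogen-bond donors and acceptors and neither carries a net charge, so those counts do not separate them. No measured property or other evidence here accounts for the step, and its cause stays unassigned.

On these data alone, with one step at this position, it remains open whether the lower number belongs to the nitrile itself or follows more generally from the removal of dimethylamino, which a primary amine, a carboxylic acid, a methyl ester or a primary amide on the same carbon could help separate. Also open, as far as these compounds go, is how far the step carries over to other cores, and whether cyano at another place on the same aromatic ring would give a similar number.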